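From a methylated aromatic group to furan-3-yl

The source may report more compounds than this note shows. Statements on the series, on what has been measured and on what is new or still open speak of the compounds shown alone.

In a functional assay on LN-229 cells (Homo sapiens) for antiproliferative activity, with a stated time of 72 h (on this read-out higher numbers stand for weaker inhibition and lower numbers for stronger inhibition), the measured compounds read as follows:
- Compound 1 `Nc1ncnn2c([C@@H]3O[C@H](CO)[C@@H](O)[C@H]3O)cc(-c3ccccc3)c12` gives 75100 nM
- Compound 2 `Cc1ccccc1-c1cc([C@@H]2O[C@H](CO)[C@@H](O)[C@H]2O)n2ncnc(N)c12` gives > 100000 nM as a limit of the assay, not a number

Compound 2 has no exact value, and its reading is the limit of > 100000 nM in this assay, at which 1 of the 2 values shown sits, in this series. Compound 3 `Nc1ncnn2c([C@@H]3O[C@H](CO)[C@@H](O)[C@H]3O)cc(-c3ccoc3)c12` keeps the shared core but carries furan-3-yl in place of 2-methylphenyl on an aromatic carbon, a change counted as furan-3-yl in place of 2-methylphenyl on an aromatic carbon here. Going by the values given here, the only measured step at this position is an at least 1.3-fold higher number from compound 1 to compound 2 (0.12 log units; that floor lies within the scatter) and it places methyl in place of hydrogen on an aromatic carbon. Among the compounds with values here, no measured step exchanges the whole aromatic group, so the evidence is thin. Since compound 1 gives 75100 nM with its own aromatic group, only a modest gain is expected in this assay and a large one is not predicted. The expected change is an at least 2.5-fold lower number from compound 2 to compound 3 (0.39 log units; beyond the scatter) and it carries wide uncertainty. For compound 3 the estimated value is 40000 nM with an expected range from 3000 nM to 100000 nM overall.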

Compound 3, half-maximal inhibitory concentration: 1000 nM
The estimate for compound 3 lay 40-fold (1.60 log units) above the measured number; the whole stated range lies above it.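

In this assay, this position proves able to carry a large change in activity, which the earlier pair had not shown: furan-3-yl in place of phenyl gives a 75-fold lower number from compound 1 to compound 3 (1.88 log units; beyond the scatter). Furan-3-yl in place of 2-methylphenyl gives an at least 100-fold lower number from compound 2 to compound 3 (2.00 log units; beyond the scatter), so the gain also holds against the methylated group. That second step is a floor and not an exact size, because compound 2 reads only as a limit of the assay: the limit of > 100000 nM in this assay, at which 1 of the 3 values shown sits.

The compounds shown cannot tell whether the gain follows the five-membered ring or its oxygen atom, since furan-3-yl differs from phenyl in both. Going by these compounds, how a thiophen-3-yl group, with sulfur in the ring, or a pyridin-3-yl group, with a six-membered ring holding nitrogen, would read at this position remains open.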